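Swapping the 3-fluorophenyl of compound 3 for pyrimidin-5-yl

The compounds below may be only part of what the source reports. "The series", "measured", "known", "first", "only" and "open" are said of these compounds alone.

Among the compounds with values here, in an ADME assay on L6 cells (Rattus norvegicus) for cytotoxicity, read by fluorescence and resazurin assay, with a stated time of 72 h (on this read-out lower numbers stand for an effect already at smaller amounts and higher numbers for an effect only at larger amounts of compound), compound 3 (`O=c1nc(-c2ccccc2)c2cc(-c3cccc(F)c3)ccc2[nH]1`) gives 23000 nM, the only value in this set that is a true number. Compound 1 (`Cc1ccc(-c2ccc3[nH]c(=O)nc(-c4ccccc4)c3c2)cn1`) gives > 50000 nM, which is a limit of the assay. Compound 2 (`O=c1nc(-c2ccccc2)c2cc(-c3ccccc3)ccc2[nH]1`) gives > 50000 nM, also a limit.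

Compound 4 (`O=c1nc(-c2ccccc2)c2cc(-c3cncnc3)ccc2[nH]1`) carries pyrimidin-5-yl in place of 3-fluorophenyl on an aromatic carbon.

Within the data shown here, two measured steps bear on this change. The first is an at least 2.1-fold lower number from compound 1 to compound 3 (0.33 log units; beyond the scatter), for 3-fluorophenyl in place of 6-methylpyridin-3-yl. The second is an at least 2.1-fold lower number from compound 2 to compound 3 (0.33 log units; beyond the scatter), for fluoro in place of hydrogen. The remaining one, a step that the two limits leave unreadable from compound 1 to compound 2, gives no usable size. Among the measured compounds shown here, both readable steps lead into compound 3, so removing the 3-fluorophenyl is expected to reverse them, although no measured compound yet carries pyrimidin-5-yl. The expected step is a 2.2-fold higher number from compound 3 to compound 4 (0.34 log units; beyond the scatter), towards a higher number. The estimate for compound 4 is 50000 nM, with an expected range of 25000 nM to 100000 nM, and a result reported only as a limit is likely.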

Compound 4, half-maximal effective concentration: > 50000 nM
Compound 4 ended at the assay's limit (the forecaster's own chance of this, stated with the estimate: 70%); the middle value lies on the limit itself.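

In this assay, pyrimidin-5-yl in place of 3-fluorophenyl gives an at least 2.1-fold higher number from compound 3 to compound 4 (0.33 log units; beyond the scatter), so a ring with 2 hetero atoms at this aromatic carbon ends at the same assay limit as the phenyl of compound 2. Among the compounds shown, the 3-fluorophenyl of compound 3 is the only group at this carbon to give a true number, while three other rings there give only a limit: the limit of > 50000 nM in this assay, at which 3 of the 4 values shown sit. The steps from compound 1 and compound 2 to compound 4 join two limits and cannot be read, so no order among these three compounds follows.

Open, on these data alone, is whether the lower number of compound 3 depends on fluoro as such or on where it sits on the phenyl ring. Also open, as far as these compounds go, is how an amine or a carboxylic acid at this carbon would read in this assay.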